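The source may report more compounds than this note shows. Statements on the series, on what has been measured and on what is new or still open speak of the compounds shown alone.

Compound 3, `COc1ccc(Oc2ccc3c(NCCCNCc4ccco4)ccnc3c2)cc1`, is the starting point here. For the measured compounds named here, in an ADME assay on HepG2 cells (Homo sapiens) for cytotoxicity, read by luminescence, CellTiter-Glo and ATP content, with a stated time of 72 h (on this read-out lower numbers stand for an effect already at smaller amounts and higher numbers for an effect only at larger amounts of compound), compound 3 gives 5300 nM, the lowest of the three numbers measured so far. Its closest neighbour is compound 1, `COc1ccccc1Oc1ccc2c(NCCCNCc3ccco3)ccnc2c1`, which in this assay gives 6500 nM; the gap between these two is within the scatter of the assay. Compound 2, `c1ccc(Oc2ccc3c(NCCCNCc4ccco4)ccnc3c2)cc1`, in this assay gives 15200 nM, and the step of a 2.9-fold lower number from compound 2 to compound 3 (0.46 log units; beyond the scatter) is beyond the scatter.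

The next compound is compound 4, `c1coc(CNCCCNc2ccnc3cc(C4CCCCC4)ccc23)c1`. It differs from compound 3 in one place: cyclohexyl in place of 4-methoxyphenoxy on an aromatic carbon.

Going by the values given here, none of the measured steps matches this change. The steps of a 2.3-fold higher number from compound 1 to compound 2 (0.37 log units; beyond the scatter) and a 2.9-fold lower number from compound 2 to compound 3 (0.46 log units; beyond the scatter) only remove or add a methoxy on the ring that now leaves, and the step of a 1.2-fold lower number from compound 1 to compound 3 (0.09 log units; within the scatter) only moves that methoxy. Nothing measured speaks to swapping the whole 4-methoxyphenoxy for a cyclohexyl, so the expectation rests on the spread of the three numbers, which all sit within a modest band.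

On that basis the expected step is a 1.5-fold higher number from compound 3 to compound 4 (0.18 log units; within the scatter), a small rise that may not exceed the scatter. Compound 4 is therefore estimated to give about 8000 nM in this assay, within a range from 3000 nM to 22000 nM.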

Compound 4, half-maximal effective concentration: 4760 nM
Beside the measured number, compound 4's estimate is 1.7-fold (0.23 log units) above it, and the stated range covers the measured number.
By their numbers in this assay, from the lowest: compounds 4, 3 and 1 (each within the scatter of the next); then compound 2.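

The result shows that this aromatic carbon tolerates far more than the small methoxy changes seen so far: in this assay, replacing the whole 4-methoxyphenoxy with cyclohexyl, a non-aromatic ring with no oxygen and fewer heavy atoms, gives a 1.1-fold lower number from compound 3 to compound 4 (0.05 log units; within the scatter). The comparisons with the other two aryl ethers differ, since a 1.4-fold lower number from compound 1 to compound 4 (0.14 log units; within the scatter) also stays within the scatter, whereas a 3.2-fold lower number from compound 2 to compound 4 (0.50 log units; beyond the scatter) goes beyond it, so compound 2 with its plain phenoxy remains apart from the other three compounds. An aromatic ring and an ether oxygen at this carbon are therefore not needed to reach the numbers of compound 1 and compound 3, although no measurement here explains why these different groups land so close together.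

The compounds shown leave open what happens when this carbon carries a group of a different kind, such as an amine or a carboxylic acid, rather than a ring of carbon atoms. The rest of the structure is the same in all four compounds, so they also cannot show what a longer chain in that part would do to this read-out.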